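Cytotoxicity notes: hydrogen in place of pyridin-4-yl

The source may hold more compounds than are shown below. What is called first, only, known or untested is meant among the compounds shown, and "the series" means these compounds.

Values in a functional assay on HL-60 cells (Homo sapiens) for cytotoxicity, read by luminescence and CellTiter-Glo, with a stated time of 3 days; on this read-out lower numbers stand for stronger inhibition and higher numbers for weaker inhibition:
compound 1 `O=C(Nc1cc(C(F)(F)F)cc(C(F)(F)F)c1)c1cc(Cl)c(-c2ccccc2)cc1O`: 790 nM
compound 2 `N#Cc1ccc(NC(=O)c2cccc3cc[nH]c23)cc1`: > 10000 nM
compound 3 `N#Cc1ccc(NC(=O)c2cc(-c3ccncc3)ccc2O)cc1`: 5410 nM

Of the two numbers in this assay, compound 3 has the higher one and compound 1 the lower. For compound 2 the result is a limit, not a number, as the limit of > 10000 nM in this assay, at which 1 of the 3 values shown sits, records. Compound 4 `N#Cc1ccc(NC(=O)c2ccccc2O)cc1` is not yet measured in this assay. It differs from compound 3 in one place: hydrogen in place of pyridin-4-yl on an aromatic carbon. No measured pair here differs in one place, so no step is shown to set a scale. With compound 3 already giving a weak 5410 nM, the expected step of a 1.7-fold higher number from compound 3 to compound 4 (0.22 log units; within the scatter) is upward, toward weaker inhibition, of a size that may exceed the scatter. Compound 4 is therefore expected at 9000 nM, between 3000 nM and 30000 nM, with a fair chance that only a limit is reported.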

Compound 4, half-maximal inhibitory concentration: 4620 nM
Compound 4: the middle estimate sits 1.9-fold (0.29 log units) above what was measured, and the stated range covers the measured number.
By their numbers in this assay, from the lowest: compound 1; then compounds 4 and 3 (each within the scatter of the next). At a limit, above all of these: compound 2.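

In this assay, among these compounds, the step of a 1.2-fold lower number from compound 3 to compound 4 (0.07 log units; within the scatter) is the first one-place comparison. On this aromatic carbon, para to a hydroxy group, replacing pyridin-4-yl with hydrogen removes a six-membered aromatic ring without a change beyond the scatter, so this read-out does not separate the two compounds. No measurement shown gives a cause for this result.

As far as these compounds go, whether an amine or a carboxylic acid at this position would move the number remains open. Compound 1 differs from compound 4 in more than one place, so this step says nothing about its value.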